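The source may hold more compounds than are shown below. What is called first, only, known or untested is meant among the compounds shown, and "the series" means these compounds.

Measured in a functional assay on thoracic aorta (Rattus norvegicus, strain Wistar), with a stated time of 15 min; a higher number here means that more compound is needed for the effect, a lower number that less compound is needed:

- Compound 1 `COc1ccc(Br)cc1C(C)NC(=O)NS(=O)(=O)c1ccc(C)cc1`: > 300000 nM
- Compound 2 `COc1ccc(Br)cc1C(C)NC(=O)N(C)S(=O)(=O)c1ccc(C)cc1`: 19100 nM
- Compound 3 `Cc1ccc(S(=O)(=O)NC(=O)NC(C)c2cc(Br)ccc2OCc2ccccc2)cc1`: 138000 nM

Compound 1 gives no number here, only a limit: > 300000 nM. Compound 4 `COc1ccc(Br)cc1C(C)NC(=O)NS(=O)(=O)c1ccc(Cl)cc1` keeps the core of compound 1 and differs in one place, with chloro in place of methyl on an aromatic carbon, the change from 4-methylphenyl to 4-chlorophenyl: chloro in place of methyl on an aromatic carbon.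

Two measured steps start from compound 1. The large one is an at least 15-fold lower number from compound 1 to compound 2 (1.19 log units; beyond the scatter), with methyl in place of hydrogen on an amide-type nitrogen. The more modest one is an at least 2.1-fold lower number from compound 1 to compound 3 (0.33 log units; beyond the scatter), with phenyl in place of hydrogen on a saturated chain carbon bound to an oxygen on an aromatic ring. Among the compounds with values here, both changes lie elsewhere in the molecule, so neither bears directly on this one, and no measured step covers this place.

No step beyond the scatter is therefore expected in this assay, and a limit may well be reported again. The expected step, an estimate only, is an at least 1.5-fold lower number from compound 1 to compound 4 (0.17 log units; that floor lies within the scatter). For compound 4 the estimated value is 200000 nM, with an expected range from 60000 nM to 300000 nM.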

Compound 4, half-maximal effective concentration: 80900 nM
The estimate for compound 4 lay 2.5-fold (0.39 log units) above the measured number, within the range that was stated.
By their numbers in this assay, from the lowest: compound 2; then compounds 4 and 3 (each within the scatter of the next). At a limit, above all of these: compound 1.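

In this assay, chloro in place of methyl on an aromatic carbon para to a large group gives an at least 3.7-fold lower number from compound 1 to compound 4 (0.56 log units; beyond the scatter). Within the data shown here, neither earlier step touched this place, so this is the first sign that the number responds to a change here, and swapping a single heavy atom is enough to produce a measurable value. The true size of the step remains unknown, and only its floor can be given, because compound 1 has a limit rather than a number: the limit of > 300000 nM in this assay, at which 1 of the 4 values shown sits.

On these data alone, whether this drop is particular to chloro remains open, since fluoro, a nitrile or an amine at this place could give a different result. Also open, as far as these compounds go, is whether chloro here and the methyl on the amide-type nitrogen of compound 2 would add up in one molecule.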